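The source may report more compounds than this note shows. Statements on the series, on what has been measured and on what is new or still open speak of the compounds shown alone.

Series notes. Compound 1 `N#Cc1c(NS(=O)(=O)c2ccc3ccccc3c2)[n+]([O-])c2ccc(Cl)cc2[n+]1[O-]` in an ADME assay on cells (Peritoneal macrophage cell, Mus musculus) for cytotoxicity, read by trypan blue exclusion, with a stated time of 48 h (on this read-out lower numbers stand for higher toxicity in this test and higher numbers for lower toxicity in this test), gives 88600 nM. Compound 2 `Cc1ccc2c(c1)[n+]([O-])c(C#N)c(NS(=O)(=O)c1ccc3ccccc3c1)[n+]2[O-]` reaches only a limit of the assay, > 245000 nM. The change methyl in place of chloro on an aromatic carbon therefore gives an at least 2.7-fold higher number from compound 1 to compound 2 (0.44 log units; beyond the scatter), which rests on (the limit of > 245000 nM in this assay, at which 1 of the 3 values shown sits). Compound 3 `CC(=O)Oc1ccccc1C(=O)Nc1c(C#N)[n+]([O-])c2cc(Cl)ccc2[n+]1[O-]` carries another core; the difference between the two cores is not broken down here. For compound 3 in this assay the outcome is "not determined" (no result reported). Compound 4 `CC(=O)Oc1ccccc1C(=O)Nc1c(C#N)[n+]([O-])c2cc(C)ccc2[n+]1[O-]` differs from compound 3 by the same change, (methyl in place of chloro on an aromatic carbon), at a place described in the same words. Compound 3 has no number, so the step to compound 4 cannot be sized from it directly. Among the compounds with values here, a step of similar direction is expected for compound 4 because an at least 2.7-fold higher number from compound 1 to compound 2 (0.44 log units; beyond the scatter) is the only measured instance of this change. For compound 4 in this assay a half-maximal cytotoxic concentration of 200000 nM is expected, estimated between 60000 nM and 450000 nM, possibly reported only as a limit.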

Compound 4, half-maximal cytotoxic concentration: 21700 nM
Beside the measured number, compound 4's estimate is 9.2-fold (0.96 log units) above it, outside the stated range (below it).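

No new step can be read: in this assay compound 3 gives "not determined" (no result reported), so the change to compound 4 cannot be sized. The compounds shown leave open whether methyl in place of chloro shifts the number in the same direction on the core of compound 4 as on the core of compound 1.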